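Swapping the aryl group on the pyridazinone nitrogen

The compounds below may be only part of what the source reports. "The series", "measured", "known", "first", "only" and "open" are said of these compounds alone.

Three compounds share one core. Compound 2 `Cc1cc(=O)n(-c2ccccc2C(F)(F)F)nc1C(=O)Nc1ccc(Oc2ncnc3sccc23)c(F)c1` and compound 3 `Cc1cc(=O)n(-c2ccc(Br)cc2F)nc1C(=O)Nc1ccc(Oc2ncnc3sccc23)c(F)c1` were tested in a functional assay on MCF7 cells (Homo sapiens) for cytotoxicity, read by MTT assay, with a stated time of 72 h; on this read-out higher numbers stand for weaker inhibition and lower numbers for stronger inhibition; compound 2 gives 13800 nM and compound 3 gives 13300 nM. The step of a 1.0-fold lower number from compound 2 to compound 3 (0.02 log units; within the scatter) lies within the scatter, so the two cannot be told apart on these numbers. Compound 1 `Cc1ccc(-n2nc(C(=O)Nc3ccc(Oc4ncnc5sccc45)cc3)c(C)cc2=O)cc1` reaches only a limit in this assay, > 40000 nM, so no number is known for it (the limit of > 40000 nM in this assay, at which 1 of the 3 values shown sits).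

Compound 4 `Cc1ccc(-n2nc(C(=O)Nc3ccc(Oc4ncnc5sccc45)c(F)c3)c(C)cc2=O)cc1` has not been measured. It differs from compound 3 by 4-methylphenyl in place of 4-bromo-2-fluorophenyl on an aromatic nitrogen. The step from compound 2 to compound 3 concerns a different pair of groups and does not bear on this change. What does bear on it is compound 1, which carries the same 4-methylphenyl group as compound 4 and shows only a limit. Compound 4 is therefore expected to give a weaker result than compound 3, a step of a 2.6-fold higher number from compound 3 to compound 4 (0.42 log units; beyond the scatter), quite possibly again reported only as a limit. The estimate for compound 4 is 35000 nM, with a range from 12000 nM to 100000 nM.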

Compound 4, half-maximal inhibitory concentration: > 40000 nM
Compound 4 was reported as a limit (the forecaster's own chance of this, stated with the estimate: 60%); middle value at least 1.1-fold (0.05 log units) away from the limit.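

With the fluoro on the aromatic carbon held the same, the aryl group on the aromatic nitrogen can now be judged alone in this assay, and 4-methylphenyl does worse than either halogen-bearing group: an at least 3.0-fold higher number from compound 3 to compound 4 (0.47 log units; beyond the scatter) and an at least 2.8-fold higher number from compound 2 to compound 4 (0.46 log units; beyond the scatter), both beyond the scatter and both only minimum sizes. The result for compound 4 is a limit and not a number, so the fluoro step from compound 1, which also stands at a limit, cannot be read: the limit of > 40000 nM in this assay, at which 2 of the 4 values shown sit. Even so, the fluoro does not bring the 4-methylphenyl compound down to a measurable number in this assay.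

Going by these compounds, how far past the limit compound 4 truly lies remains unknown. Also open, on these data alone, is whether a plain phenyl, or an aryl group carrying a methoxy or an amine, would behave like 4-methylphenyl or like 4-bromo-2-fluorophenyl.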